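A few compounds are considered here, and "the series" means these few. Any claim that something is new, unique, unknown or untested is made for them only; others in the source may bear on it.

Of the compounds shown here, three have so far been measured in an assay on isolated protein for binding affinity to Equilibrative nucleoside transporter 1 (Homo sapiens); a higher number here means a weaker inhibitor, a lower number a stronger inhibitor. Compound 1 `O=[N+]([O-])c1ccc2c(c1)CCN(c1ncnc3c1ncn3[C@@H]1O[C@H](CO)[C@@H](O)[C@H]1O)C2` gives 182 nM, compound 2 `CCCCCNc1ncnc2c1ncn2[C@@H]1O[C@H](CO)[C@@H](O)[C@H]1O` gives 13500 nM, and compound 3 `CCC(C)Sc1nc(N)nc2c1ncn2[C@@H]1O[C@H](CO)[C@@H](O)[C@H]1O` gives 63100 nM. Compound 2 therefore holds the second highest of the three numbers: compound 3 sits above it and compound 1 far below it, both gaps beyond the usual scatter. Compound 4 `OC[C@H]1O[C@@H](n2cnc3c(CSc4ccccc4F)ncnc32)[C@H](O)[C@@H]1O` has not yet been measured in this assay. It differs from compound 2 in one place: ((2-fluorophenyl)sulfanyl)methyl in place of pentylamino on an aromatic carbon. Among the measured compounds shown here, no pair of measured compounds differing in only one place is available to calibrate this change. Among the measured compounds only compound 1 carries an aromatic ring on the shared core, and its value of 182 nM is the lowest of the three; this is the nearest pointer for compound 4. The expected step, a 5.4-fold lower number from compound 2 to compound 4 (0.73 log units; beyond the scatter), is a moderate drop in the number. For compound 4 the estimated value is 2500 nM, within a range from 300 nM to 15000 nM.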

Compound 4, half-maximal inhibitory concentration: 355 nM
Compound 4: the middle estimate sits 7.0-fold (0.85 log units) above what was measured; the measured number falls inside the stated range.
By their numbers in this assay, from the lowest: compounds 1 and 4 (each within the scatter of the next); then compound 2; then compound 3.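

Among the compounds shown here, the step of a 38-fold lower number from compound 2 to compound 4 (1.58 log units; beyond the scatter) is the first single-place comparison in this assay, and it shows that this aromatic carbon of the shared core responds strongly to the group it carries. The change alters several things at once, bringing in an aromatic ring, a sulfur and a fluorine and removing the hydrogen-bond donor of pentylamino, so the step cannot be divided among them. No measurement here explains its size. The compounds shown leave open which of these parts matters; phenylsulfanylmethyl without the fluorine, or a benzyloxy group without the sulfur, would begin to separate them.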